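Fluoronaphthyl pyridinone series: microsomal half-life notes

This account rests on a few compounds, and the source may have more. Where it says the series, first, only, none or still open, it means among the compounds named here.

Measured so far:
- compound 1 `CC(C)C(/C=C1\CCNC1=O)c1ccc(-c2ccc3cccc(F)c3c2)[nH]c1=O`: 0.713 h
- compound 2 `CCC(CC)(c1nnc[nH]1)c1ccc(-c2ccc3cccc(F)c3c2)[nH]c1=O`: 1.19 h

In an ADME assay on microsomes from liver (Homo sapiens) for metabolic stability (a higher number here means that the compound lasts longer, a lower number that the compound disappears faster), compound 1 gives 0.713 h and compound 2 gives 1.19 h. Compound 1 gives the smaller of the two numbers, but the gap to compound 2 lies within the scatter, so the two are not told apart by this assay. Among the compounds with values here, no step between compounds differing in a single place is available, so no measured step size can be quoted.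

Compound 3 `Cc1c[nH]c(C(c2ccc(-c3ccc4cccc(F)c4c3)[nH]c2=O)C(C)C)n1` has not yet been measured. Relative to compound 1 it carries a group of 6 heavy atoms (4 carbon, 2 nitrogen; one five-membered aromatic ring with 2 hetero atoms) in place of a group of 7 heavy atoms (5 carbon, 1 nitrogen, 1 oxygen; one five-membered non-aromatic ring with 1 hetero atom), on a saturated chain carbon bound to an aromatic carbon and a saturated chain carbon. With only the numbers above as a guide, the expected step is small: compound 3 is estimated to sit close to compound 1 and compound 2, with a step of a 1.3-fold higher number from compound 1 to compound 3 (0.12 log units; within the scatter) that stays within the scatter. The expected value for compound 3 in this assay is 0.95 h, ranging from 0.45 h to 2 h.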

Compound 3, half-life: 0.09 h
Compound 3: the middle estimate sits 11-fold (1.02 log units) above what was measured; the whole stated range lies above it.
By their numbers in this assay, from the lowest: compound 3; then compounds 1 and 2 (each within the scatter of the next).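

At the saturated chain carbon bound to an aromatic carbon and a saturated chain carbon, the identity of the group clearly matters in this assay: putting 4-methyl-1H-imidazol-2-yl in place of the non-aromatic ring group gives a 7.9-fold lower number from compound 1 to compound 3 (0.90 log units; beyond the scatter) and takes the series beyond the scatter. Within the data shown here, the earlier pair offered no step between compounds differing in one place, so this is the first measured sign that a change here alone can shift the half-life. No available measurement accounts for this step.

The compounds shown do not separate the contribution of the imidazole ring from that of its methyl group, and compound 2 differs from compound 3 in more than one place, so it cannot settle this. On these data alone, how an open-chain amide or a carboxylic acid at this place would behave in this assay remains open.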